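This account rests on a few compounds, and the source may have more. Where it says the series, first, only, none or still open, it means among the compounds named here.

Measured compounds:
compound 1 `COC(=O)c1ccc(N2CCC(O)(Cn3cnc4c(Br)n(C)nc4c3=O)CC2)c(Cl)c1`: 157 nM
compound 2 `O=c1c2cnn(-c3ccc(F)cc3)c2ncn1CC1(O)CCN(Cc2ccccc2)CC1`: "not determined" (no result reported)
compound 3 `O=c1c2cnn(-c3ccc(F)cc3)c2ncn1CC1(O)CCN(Cc2cccnc2)CC1`: "not determined" (no result reported)

In an assay on Sf21 cells for inhibition of ubiquitin carboxyl-terminal hydrolase 7 (Homo sapiens), read by spectrophotometry, with stated times of 30 min and 2 h (a lower number here means a stronger inhibitor, a higher number a weaker inhibitor), compound 1 gives 157 nM. Compound 2 has no result in this assay, and compound 3 stands at "not determined" (no result reported) in this assay, so there is no number for it; compound 2 is the other entry without one. Going by the values given here, no step between two measured compounds is available, and compound 1 shares no close structure with compound 3.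

Compound 4 `O=c1c2cnn(-c3ccc(F)cc3)c2ncn1CC1(O)CCN(Cc2ccccc2F)CC1` is to be measured in this assay. Its difference from compound 3 is 2-fluorophenyl in place of pyridin-3-yl on a saturated chain carbon bound to an amine nitrogen in a ring, the change reading, one bond further out, as (pyridin-3-yl)methyl to 2-fluorobenzyl. Since compound 3 has no number, the size and direction of the step in this assay cannot be read; no expectation of a change beyond the scatter can be drawn from the data.

For compound 4 in this assay the expected value is 800 nM, within a range from 80 nM to 8000 nM, resting only on compound 1 at 157 nM as the single anchor.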

Compound 4, half-maximal inhibitory concentration: 9800 nM
Compound 4: the middle estimate sits 12-fold (1.09 log units) below what was measured; the measured number lies above the stated range.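

In this assay, going by these compounds alone, compound 3 has no single number, so no step to compound 4 at 9800 nM can be read. The compounds shown leave open how (pyridin-3-yl)methyl and 2-fluorobenzyl compare on the shared core in this assay. No supporting evidence bears on this result.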